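This account rests on a few compounds, and the source may have more. Where it says the series, first, only, none or still open, it means among the compounds named here.

Compound 3, `C=CC1=C(C(=O)Nc2ccccc2OC)C(c2ccc(OC)cc2)OC1`, is the starting point of this step. In a functional assay on QGY7701 cells (Homo sapiens) for cytotoxicity, read by MTT assay, with a stated time of 24 h (on this read-out higher numbers stand for weaker inhibition and lower numbers for stronger inhibition), compound 3 gives only a limit of the assay, > 100000 nM. Compound 2, `C=CC1=C(C(=O)Nc2ccccc2OC)C(c2ccc(F)cc2)OC1`, gives 52800 nM in this assay. Within the data shown here, the single measured step is an at least 1.8-fold higher number from compound 2 to compound 3 (0.27 log units; that floor lies within the scatter). Compound 1, `C=CC1=C(C(=O)Nc2ccccc2)C(c2ccc(Cl)c(Cl)c2)OC1`, carries the 3,4-dichlorophenyl group together with an unsubstituted anilide. In this assay compound 1 also gives only a limit, > 100000 nM. Compound 4, `C=CC1=C(C(=O)Nc2ccccc2OC)C(c2ccc(Cl)c(Cl)c2)OC1`, has not yet been measured; it differs from compound 3 as 3,4-dichlorophenyl in place of 4-methoxyphenyl on a saturated ring carbon. No measured step covers this exchange of the aryl group: the one step shown, an at least 1.8-fold higher number from compound 2 to compound 3 (0.27 log units; that floor lies within the scatter), concerns a different ring, so the only guide is compound 1 at the limit of > 100000 nM in this assay, at which 2 of the 3 values shown sit. Because compound 1 stands at the limit of > 100000 nM in this assay, at which 2 of the 3 values shown sit, compound 4 is expected to show a number no higher from compound 3 to compound 4 (the limit leaves the size open), that is, nothing beyond the scatter. Compound 4 is therefore estimated at 100000 nM, within a range from 40000 nM to 300000 nM, and the assay will most likely again report only a limit.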

Compound 4, half-maximal inhibitory concentration: > 100000 nM
Compound 4: only a limit was reported; the forecaster's own chance of this, stated with the estimate: 60%; the middle value lies on the limit itself.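

With 3,4-dichlorophenyl on the saturated ring carbon next to the ring oxygen, compound 4 gives only a limit in this assay, > 100000 nM. Exchanging 4-fluorophenyl for 3,4-dichlorophenyl at this position gives an at least 1.8-fold higher number from compound 2 to compound 4 (0.27 log units; that floor lies within the scatter), so this change, too, shows no shift beyond the scatter. The steps joining compound 4 to compound 3 and to compound 1 cannot be read, and the limit now covers most of the compounds, whether the anilide carries methoxy or hydrogen: the limit of > 100000 nM in this assay, at which 3 of the 4 values shown sit.

Going by these compounds, only compound 2 gives a number that is not a limit, 52800 nM, and whether any aryl group at this position can lower that number beyond the scatter stays open. The compounds shown also leave open how an amine or a carboxylic acid on this aryl ring, or a longer chain in place of the vinyl group, would read in this assay.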